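Amino in place of hydroxy in compound 2

The source may hold more compounds than are shown below. What is called first, only, known or untested is meant among the compounds shown, and "the series" means these compounds.

Three related compounds have been measured in a functional assay on HeLa cells (Homo sapiens) for antiproliferative activity, read by MTT assay, with a stated time of 48 h; a lower number here means a stronger inhibitor, a higher number a weaker inhibitor. There, compound 1 (`COc1ccc(C(=O)c2ccc(OC)c3c2C=CC(C)(C)O3)c(NC(=O)CN)c1`) gives 100 nM, compound 2 (`C=C(c1ccc2c(c1)C=CC(C)(C)O2)c1ccc(OC)cc1NC(=O)CO`) gives 100 nM and compound 3 (`C=C(c1ccc(OC)cc1NC(=O)CN)c1ccc(OC)c2c1C=CC(C)(C)O2`) gives 200 nM. Compound 2 thus stands level with compound 1, and its gap to compound 3 stays within the usual scatter.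

Compound 4 (`C=C(c1ccc2c(c1)C=CC(C)(C)O2)c1ccc(OC)cc1NC(=O)CN`) has not yet been measured. It departs from compound 2 at a single place: amino in place of hydroxy on a saturated chain carbon bound to a carbonyl carbon.

Among the measured compounds shown here, no measured pair isolates this change, so its size cannot be read directly. Still, compound 1 at 100 nM and compound 3 at 200 nM both carry the aminomethyl group and remain within the scatter of compound 2, so no step beyond the scatter is expected in this assay. The expected step is a 1.2-fold higher number from compound 2 to compound 4 (0.08 log units; within the scatter), a change within the scatter. For compound 4 the estimated value is 120 nM, with an expected range of 45 nM to 300 nM.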

Compound 4, half-maximal inhibitory concentration: 160 nM
Estimate against measurement, compound 4: 1.3-fold (0.12 log units) below, and the stated range covers the measured number.
By their numbers in this assay, from the lowest: compounds 1, 2, 4 and 3 (each within the scatter of the next).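

In this assay, the change of hydroxy to amino on a saturated chain carbon bound to a carbonyl carbon can now be read directly, as a 1.6-fold higher number from compound 2 to compound 4 (0.20 log units; within the scatter) for this single replacement. Among the compounds shown here, on this core, hydroxy and amino are therefore not separated at this position, which the earlier compounds could not show, as none of them formed a pair for this change. Nothing given here bears on why the two groups read alike.

Whether hydroxy and amino also read alike on the cores of compound 1 and compound 3 remains open, as neither compound has a hydroxy partner among those shown. Also open, from the compounds shown here alone, is how a dimethylamino group, a carboxylic acid or a longer chain would read at this place in this assay.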